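The source may hold more compounds than are shown below. What is called first, only, known or untested is meant among the compounds shown, and "the series" means these compounds.

Compound 3 `CCOc1ccc(/C=N/NC(=O)c2cnccn2)cc1` holds the highest reading of the three in an ADME assay on J774 cells (Mus musculus) for cytotoxicity, read by MTT assay, with a stated time of 48 h, tested at 150 ug/mL (a lower number here means a stronger effect, a higher number a weaker effect of the compound at the concentration tested), where compound 3 gives 100%. Compound 1 `O=C(N/N=C/c1ccc(Cl)cc1)c1cnccn1` gives 56% in this assay, and compound 2 `COc1ccc(/C=N/NC(=O)c2cnccn2)cc1` gives 55%. The two steps that lead up to compound 3 are both large: a number 44 percentage points higher from compound 1 to compound 3 (beyond the scatter) and a number 45 percentage points higher from compound 2 to compound 3 (beyond the scatter), whereas the remaining pair shows a number 1 percentage points lower from compound 1 to compound 2 (within the scatter).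

Compound 4 `O=C(N/N=C/c1ccc(O)cc1)c1cnccn1` is reached from compound 3 by a single change: hydrogen in place of ethyl on an oxygen on an aromatic ring. Among the measured compounds shown here, the step that bears most directly on this move is the one between compound 2 and compound 3, where a methyl in place of hydrogen on a saturated chain carbon bound to an oxygen on an aromatic ring brought a number 45 percentage points higher from compound 2 to compound 3 (beyond the scatter). The move to compound 4 runs the other way, stripping the ethyl from that oxygen altogether, so the reading in this assay is expected to fall back, and the expected step is a number 45 percentage points lower from compound 3 to compound 4 (beyond the scatter). For the measured compounds named here, no measured compound carries a free hydroxy, so compound 4 may land near compound 2 or lower still. On that basis compound 4 is estimated at 55%, with a range from 35% to 80%.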

Compound 4, a percentage reported as activity, at one concentration (the size of the read-out at that concentration, not a potency): 80%
For compound 4 the middle estimate is 25 percentage points below the measured one; measured number inside the range.
By their numbers in this assay, from the lowest: compounds 2 and 1 (each within the scatter of the next); then compound 4; then compound 3.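

Removing the ethyl from the oxygen on the aromatic ring does not carry the reading in this assay back to the level of the methoxy compound: there is a number 20 percentage points lower from compound 3 to compound 4 (beyond the scatter), but also a number 25 percentage points higher from compound 2 to compound 4 (beyond the scatter). The reading therefore does not follow the length of the group on that oxygen, since hydrogen in compound 4 falls between methyl in compound 2 and ethyl in compound 3, and compound 4 goes against any steady climb from hydrogen through methyl to ethyl. The hydroxy also separates from chloro, with a number 24 percentage points higher from compound 1 to compound 4 (beyond the scatter), whereas methoxy and chloro had stayed together at a number 1 percentage points lower from compound 1 to compound 2 (within the scatter), and nothing available accounts for where the hydroxy falls.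

On these data alone, what remains open is whether a longer chain on that oxygen, such as propoxy or butoxy, would stay with ethoxy at the top of this series or drop back. As far as these compounds go, it is equally open where an amine or a carboxylic acid on the same aromatic carbon would fall relative to the hydroxy, and these readings, each taken at one concentration, give no potency for any of the compounds.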